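The source may hold more compounds than are shown below. What is called first, only, known or untested is meant among the compounds shown, and "the series" means these compounds.

For the measured compounds named here, compound 2 `COc1cc2c(Oc3ccc(NC(=O)c4cc(-c5ccccc5F)ccn4)cc3F)ccnc2cc1OCCCN1CCCCC1` gives 180 nM in a functional assay on MKN-45 cells (Homo sapiens) for cytotoxicity, read by MTT assay, with a stated time of 72 h (on this read-out lower numbers stand for stronger inhibition and higher numbers for weaker inhibition), the lowest of the two numbers known so far. Going by the values given here, its nearest neighbour, compound 1 `COc1cc2c(Oc3ccc(NC(=O)c4cc(-c5ccc(F)cc5)ccn4)cc3F)ccnc2cc1OCCCN1CCCCC1`, gives 1240 nM in this assay, and the single measured step, a 6.9-fold lower number from compound 1 to compound 2 (0.84 log units; beyond the scatter), concerns the fluorophenyl group. Compound 3 `COc1cc2c(Oc3ccc(NC(=O)c4cc(-c5ccccc5F)ccn4)cc3F)ccnc2cc1OCCCN1CCN(C)CC1` has not yet been measured. It differs from compound 2 in one place: 4-methylpiperazin-1-yl in place of piperidin-1-yl on a saturated chain carbon, three bonds along the chain from an oxygen on an aromatic ring. Among the compounds with values here, no measured step bears on this part of the molecule; the one step known lies on the other side of the shared core and says nothing about the saturated chain or the ring at its end. With nothing to point either way, the expected step is a 1.1-fold higher number from compound 2 to compound 3 (0.05 log units; within the scatter), no larger than the scatter. Compound 3 is therefore estimated at 200 nM in this assay, within a range from 70 nM to 600 nM.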

Compound 3, half-maximal inhibitory concentration: 150 nM
Beside the measured number, compound 3's estimate is 1.3-fold (0.12 log units) above it; the range from low to high includes it.
By their numbers in this assay, from the lowest: compounds 3 and 2 (each within the scatter of the next); then compound 1.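

For the compounds shown here, the first change at the end of the saturated chain, with 4-methylpiperazin-1-yl in place of piperidin-1-yl, gives a 1.2-fold lower number from compound 2 to compound 3 (0.08 log units; within the scatter) in this assay, so the two rings cannot be told apart here, despite the second ring nitrogen and the added methyl. This position therefore accepts this exchange with no measurable cost, whereas moving the fluorine on the other side of the shared core gave a 6.9-fold lower number from compound 1 to compound 2 (0.84 log units; beyond the scatter). Nothing further is at hand that would explain why the exchange leaves the cytotoxicity reading where it was.

Open, going by these compounds, is whether a morpholin-4-yl ring, a dimethylamino group or a plain hydroxyl group at the end of the chain, or a shorter chain, would keep the number in this range. On these data alone, it also remains open whether the same exchange would read alike with the 4-fluorophenyl group of compound 1.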